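Hydroxy to methoxy on compound 2

This account rests on a few compounds, and the source may have more. Where it says the series, first, only, none or still open, it means among the compounds named here.

In a functional assay on Raji cells (Homo sapiens) for inhibition, read by MTT assay, with a stated time of 72 h (a lower number here means a stronger inhibitor, a higher number a weaker inhibitor), compound 2 (`CO[C@@H](c1ccccc1)[C@H]1O[C@@H]2CC(=O)O[C@@H]2[C@H]1O`) gives 21100 nM. Compound 1 (`CO[C@@H]1[C@H]2OC(=O)C[C@H]2O[C@@H]1[C@@H](O)c1ccccc1`) gives 12200 nM. Compound 3 (`CO[C@H](c1ccccc1)[C@H]1O[C@@H]2CC(=O)O[C@@H]2[C@H]1O`) gives 15600 nM. All three numbers stand within the scatter of one another, so compound 2 holds no separate place among them.

Compound 4 (`CO[C@@H]1[C@H]2OC(=O)C[C@H]2O[C@@H]1[C@@H](OC)c1ccccc1`) differs from compound 2 by methyl in place of hydrogen on an oxygen on a saturated carbon, that is, hydroxy to methoxy. Among the measured compounds shown here, no measured step makes this change. For the measured compounds named here, the only measured step, a 1.4-fold lower number from compound 2 to compound 3 (0.13 log units; within the scatter), is a matter of configuration alone (the fact that compounds 2 and 3 differ only in the configuration as drawn) and bears on the new change only indirectly. The values of compound 1 and compound 2 show no gap beyond the scatter either.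

A step beyond the scatter is therefore not expected in this assay, and neither direction is favoured. The estimated change is a 1.3-fold lower number from compound 2 to compound 4 (0.12 log units; within the scatter), which stays within the scatter. For compound 4 the expected value is 16000 nM, with an estimated range of 7000 nM to 38000 nM.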

Compound 4, half-maximal inhibitory concentration: 10500 nM
For compound 4 the middle estimate is 1.5-fold (0.18 log units) above the measured one, and the stated range covers the measured number.
By their numbers in this assay, from the lowest: compounds 4, 1, 3 and 2 (each within the scatter of the next).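

In this assay hydroxy to methoxy can now be read on two different oxygens, with a 2.0-fold lower number from compound 2 to compound 4 (0.30 log units; within the scatter) at one oxygen and a 1.2-fold lower number from compound 1 to compound 4 (0.07 log units; within the scatter) at the other oxygen. Neither hydrogen is needed to hold the number in this range: compound 4, with methoxy on both oxygens and no hydroxy left, stays within the scatter of compound 1 and of compound 2. Nothing at hand gives a reason for these numbers.

The compounds shown leave open whether either oxygen accepts anything larger than methyl, since all of them carry only hydroxy or methoxy there. An amine in place of either oxygen, or a longer chain such as ethoxy or a carboxylic acid on it, could show whether any step beyond the scatter exists at these places.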